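The source may hold more compounds than are shown below. What is called first, only, known or untested is meant among the compounds shown, and "the series" means these compounds.

Measured compounds:
compound 1 `O=C1O[C@@H](CN2CCC(O)CC2)CN1c1ccc(-n2cc(-c3ccccn3)cn2)c(F)c1` in an ADME assay on HEK293-A cells (Homo sapiens) for cytotoxicity, read by MTT assay, with a stated time of 48 h; a lower number here means a stronger inhibitor, a higher number a weaker inhibitor: compound 1 gives > 400 ug/mL, which is a limit of the assay and not a number.
compound 2 `O=C1O[C@@H](CSc2cccs2)CN1c1ccc(-n2cc(-c3ccccn3)cn2)c(F)c1`: compound 2 gives > 400 ug/mL, again a limit and not a number.
compound 3 `CCC(=O)NC[C@H]1CN(c2ccc(-n3cc(-c4ccccn4)cn3)c(F)c2)C(=O)O1`: compound 3 gives 389 ug/mL.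

Among the measured compounds shown here, compound 3 is thus the only compound of the three with a number in this assay; the two other values are limits, as the shared line the limit of > 400 ug/mL in this assay, at which 2 of the 3 values shown sit, shows. Compound 4 `CCNC(=O)NC[C@H]1CN(c2ccc(-n3cc(-c4ccccn4)cn3)c(F)c2)C(=O)O1` differs from compound 3 by one change: ethylamino in place of ethyl on a carbonyl carbon. For the measured compounds named here, two measured steps bear on this position on the saturated chain carbon, an at least 1.0-fold lower number from compound 1 to compound 3 (0.01 log units; that floor lies within the scatter) and an at least 1.0-fold lower number from compound 2 to compound 3 (0.01 log units; that floor lies within the scatter), and both can only be read as floors that lie within the scatter; the step that the two limits leave unreadable from compound 1 to compound 2 gives no readable size. The numbers therefore show no movement at this site that exceeds the scatter, and a step from compound 3 to compound 4 of no more than the scatter is expected, in either direction, with a fair chance that only a limit is reported. Compound 4 is estimated at 390 ug/mL, in the range 200 ug/mL to 800 ug/mL, an expected step of a 1.0-fold higher number from compound 3 to compound 4 (0.00 log units; within the scatter).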

Compound 4, half-maximal inhibitory concentration: 29 ug/mL
For compound 4 the middle estimate is 13-fold (1.13 log units) above the measured one; measured number below the stated range.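

In this assay the carbonyl carbon of the side chain proves to be a sensitive place: ethylamino in place of ethyl, which turns propanoylamino into (ethylcarbamoyl)amino, gives a 13-fold lower number from compound 3 to compound 4 (1.13 log units; beyond the scatter), whereas no earlier step could be read as exceeding the scatter. The steps from the two other side chains, an at least 13-fold lower number from compound 2 to compound 4 (1.13 log units; beyond the scatter) and an at least 13-fold lower number from compound 1 to compound 4 (1.13 log units; beyond the scatter), also lie beyond the scatter. Both are only floors because compound 1 and compound 2 each carry a limit and not a number: the limit of > 400 ug/mL in this assay, at which 2 of the 4 values shown sit.

The compounds shown leave open whether the lower number goes with the nitrogen that enters or with the ethyl group it carries. They also leave open whether methylamino, dimethylamino or a longer chain such as butylamino on the same carbonyl carbon would move the number as far.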